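Aryl change on the hydrazone terminus of compound 1

A few compounds are considered here, and "the series" means these few. Any claim that something is new, unique, unknown or untested is made for them only; others in the source may bear on it.

Compounds measured so far:
- compound 1 `CN(C)CCn1cnnc1-c1cc(Oc2ccc(NC(=O)N/N=C/c3ccc(Cl)cc3Cl)cc2F)ccn1`: 4760 nM
- compound 2 `CN(C)CCn1cnnc1-c1cc(Oc2ccc(NC(=O)N/N=C/c3c[nH]c4ccccc34)cc2F)ccn1`: 3620 nM
- compound 3 `CN(C)CCn1cnnc1-c1cc(Oc2ccc(NC(=O)N/N=C/c3cccc(Cl)c3Cl)cc2F)ccn1`: 6130 nM

In an ADME assay on WI-38 cells (Homo sapiens) for cytotoxicity, read by MTT assay, with a stated time of 72 h (on this read-out lower numbers stand for stronger inhibition and higher numbers for weaker inhibition), compound 1 gives 4760 nM. Among the three numbers it stands second highest; its nearest neighbour is compound 3, and the step of a 1.3-fold higher number from compound 1 to compound 3 (0.11 log units; within the scatter) lies within the scatter, as does the step of a 1.3-fold lower number from compound 1 to compound 2 (0.12 log units; within the scatter) to its furthest neighbour. The step of a 1.7-fold higher number from compound 2 to compound 3 (0.23 log units; within the scatter) is also within the scatter, so the three measured compounds cannot be told apart on this read-out.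

Compound 4 `CN(C)CCn1cnnc1-c1cc(Oc2ccc(NC(=O)N/N=C/c3cccc(Br)c3)cc2F)ccn1` has not yet been measured in this assay. It differs from compound 1 in one place: 3-bromophenyl in place of 2,4-dichlorophenyl on a carbon with a double bond to nitrogen. Going by the values given here, the steps that bear on this change are a 1.3-fold higher number from compound 1 to compound 3 (0.11 log units; within the scatter) and a 1.3-fold lower number from compound 1 to compound 2 (0.12 log units; within the scatter), both of which exchange the group on the carbon with a double bond to nitrogen, and both of which stay within the scatter. Among the compounds with values here, since every exchange at this position so far left the number where it was, no step beyond the scatter is expected for compound 4 either, and the estimated step of a 1.1-fold higher number from compound 1 to compound 4 (0.02 log units; within the scatter) reflects that. Compound 4 is therefore expected to give about 5000 nM, with a range from 2500 nM to 10000 nM.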

Compound 4, half-maximal inhibitory concentration: 4230 nM
For compound 4 the middle estimate is 1.2-fold (0.07 log units) above the measured one; low and high end bracket the measured number.
By their numbers in this assay, from the lowest: compounds 2, 4, 1 and 3 (each within the scatter of the next).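

In this assay, exchanging 2,4-dichlorophenyl for 3-bromophenyl on the carbon with a double bond to nitrogen replaces two chlorine atoms with one bromine and goes from 8 heavy atoms to 7, yet the step stays within the scatter (a 1.1-fold lower number from compound 1 to compound 4 (0.05 log units; within the scatter)). Compound 4 also stays within the scatter of the other two compounds (a 1.4-fold lower number from compound 3 to compound 4 (0.16 log units; within the scatter); a 1.2-fold higher number from compound 2 to compound 4 (0.07 log units; within the scatter)), so a ring with a single bromine cannot be told apart from the two dichlorophenyl rings or the 1H-indol-3-yl group, and none of the four compounds goes against this flat picture. No measurement offered here accounts for this lack of separation.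

All four groups at this place are aromatic rings, so the compounds leave open whether a saturated cyclohexyl group, or a phenyl ring carrying a carboxylic acid or an amine, would move the number beyond the scatter. They also leave open whether the cytotoxicity depends on the shared core, since the dimethylaminoethyl chain is the same throughout and no compound with a longer chain or a different amine is shown.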